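The compounds below may be only part of what the source reports. "The series", "measured", "known", "first", "only" and "open" are said of these compounds alone.

Going by the values given here, in a functional assay on cells (Cancer cell lines, Homo sapiens) for cytotoxicity, read by sulforhodamine B assay, with a stated time of 48 h (on this read-out higher numbers stand for weaker inhibition of growth and lower numbers for stronger inhibition of growth), compound 2 `COc1ccc(C2=NN(C3=NC(=O)/C(=C4\C(=O)Nc5ccccc54)S3)C(c3ccc(Cl)cc3)C2)cc1` gives 100000 nM, the higher of the two numbers known so far; compound 1 `O=C1N=C(N2N=C(c3ccccc3)CC2c2ccc(Cl)cc2)S/C1=C1/C(=O)Nc2ccccc21` gives 390 nM, and the change from compound 1 to compound 2, a methoxy in place of hydrogen on an aromatic carbon, brought a 260-fold higher number from compound 1 to compound 2 (2.41 log units; beyond the scatter). Compound 3 `COc1ccc(C2=NN(C3=NC(=O)/C(=C4\C(=O)Nc5ccc(Cl)cc54)S3)C(c3ccc(Cl)cc3)C2)cc1` differs from compound 2 by chloro in place of hydrogen on an aromatic carbon. Among the compounds with values here, no measured step touches that ring or that group, so the change from compound 2 to compound 3 is expected to be small, within the scatter, a 1.7-fold lower number from compound 2 to compound 3 (0.22 log units; within the scatter). Compound 3 is therefore estimated at 60000 nM, with a range from 15000 nM to 150000 nM.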

Compound 3, concentration for total growth inhibition: 450 nM
Compound 3: middle estimate off by 130-fold (2.12 log units), on the high side; measured number below the stated range.
By their numbers in this assay, from the lowest: compounds 1 and 3 (each within the scatter of the next); then compound 2.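

In this assay, going by these compounds alone, the first measured change on the fused two-ring system, chloro in place of hydrogen on an aromatic carbon, gives a 220-fold lower number from compound 2 to compound 3 (2.35 log units; beyond the scatter). This position is therefore highly sensitive, even though a single chlorine is the only difference, and the methoxy group does not fix the outcome on its own. No available evidence explains a shift of this size. Going by these compounds, whether the same chloro would have a comparable effect on compound 1, which lacks the methoxy, remains open. So does the outcome with fluoro, methyl or an amine at this position.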